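From hydrogen to methoxy on an aromatic carbon

The compounds below may be only part of what the source reports. "The series", "measured", "known", "first", "only" and "open" are said of these compounds alone.

Two compounds have been measured so far in a functional assay on A549 cells (Homo sapiens) for antiproliferative activity, read by MTT assay, with a stated time of 48 h; a higher number here means a weaker inhibitor, a lower number a stronger inhibitor:

compound 1 `C#Cc1cccc(NC(=O)c2cc(NC(=O)CCCCCC(=O)NO)ccc2O)c1` gives 76200 nM
compound 2 `C#Cc1cccc(NC(=O)c2cccc(NC(=O)CCCCCC(=O)NO)c2)c1` gives 37600 nM

Compound 2 at 37600 nM holds the lower of the two numbers, which makes it the stronger inhibitor of the pair. The unmeasured compound 3 `C#Cc1cccc(NC(=O)c2cc(NC(=O)CCCCCC(=O)NO)ccc2OC)c1` differs from compound 2 by methoxy in place of hydrogen on an aromatic carbon. This is the aromatic carbon that carries hydroxy in compound 1. One measured step therefore bears on the change, namely a 2.0-fold lower number from compound 1 to compound 2 (0.31 log units; beyond the scatter) with hydrogen in place of hydroxy on an aromatic carbon. Among the compounds with values here, no measured compound carries methoxy, so that step offers only a rough guide. Going by compound 1 at 76200 nM in this assay, a modest rise in the number is expected, of about the same size or a little smaller. The expected step is a 1.6-fold higher number from compound 2 to compound 3 (0.20 log units; within the scatter) by this estimate. Compound 3 is expected at 60000 nM within a range of 25000 nM to 130000 nM by this estimate.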

Compound 3, half-maximal inhibitory concentration: 40700 nM
Beside the measured number, compound 3's estimate is 1.5-fold (0.17 log units) above it; the range from low to high includes it.
By their numbers in this assay, from the lowest: compounds 2, 3 and 1 (each within the scatter of the next, the first and the last beyond it).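

In this assay, methoxy on this aromatic carbon, ortho to a large group and para to a large group, gives a 1.1-fold higher number from compound 2 to compound 3 (0.03 log units; within the scatter), so a substituent of 2 heavy atoms here leaves the reading within the scatter of the unsubstituted compound. Methyl in place of hydrogen on the oxygen gives a 1.9-fold lower number from compound 1 to compound 3 (0.27 log units; within the scatter), so compound 3 cannot be ordered against either neighbour, even though the earlier hydroxy-to-hydrogen step lay beyond the scatter. This means that, of the two oxygen-bearing groups tested at this position, only hydroxy stands apart from hydrogen, and nothing available explains this difference.

With one hydroxy compound and one methoxy compound, the three values cannot show whether the separation of hydroxy from hydrogen is a reproducible feature of this position or merely a small step just past the scatter. As far as these compounds go, it also remains open how other groups on this aromatic carbon, such as an amine, a carboxylic acid, fluorine or a longer ethoxy group, would read in this assay, and whether any of them would move the number beyond the scatter in either direction.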